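Replacing Phenyl with Ethoxycarbonyl on an Aromatic Carbon

A few compounds are considered here, and "the series" means these few. Any claim that something is new, unique, unknown or untested is made for them only; others in the source may bear on it.

Of the compounds shown here, three sharing one core have been measured in an ADME assay on L929 cells (Mus musculus) for cytotoxicity, read by resazurin assay, with a stated time of 72 h; a lower number here means a stronger inhibitor, a higher number a weaker inhibitor. Compound 1 `Cc1ccc(C(=O)/C=C/c2ccc3c(c2)B(O)OC3)cc1` gives > 10 ug/mL, which is a limit and not a number. Compound 2 `O=C(/C=C/c1ccc2c(c1)B(O)OC2)c1ccc(Cl)cc1` gives > 10 ug/mL, again a limit. Compound 3 `O=C(/C=C/c1ccc2c(c1)B(O)OC2)c1ccc(-c2ccccc2)cc1` also gives only a limit, > 10 ug/mL, so its place in the series cannot be ranked against the other two.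

The change to compound 4 `CCOC(=O)c1ccc(C(=O)/C=C/c2ccc3c(c2)B(O)OC3)cc1` is ethoxycarbonyl in place of phenyl on an aromatic carbon. Among the compounds with values here, three measured steps bear on it, each a swap of one group on an aromatic carbon: a step that the two limits leave unreadable from compound 1 to compound 2, a step that the two limits leave unreadable from compound 1 to compound 3 and a step that the two limits leave unreadable from compound 2 to compound 3. None of them has a size that can be read. With the limit of > 10 ug/mL in this assay, at which 3 of the 3 values shown sit, the series offers no direction, and no step beyond the scatter is expected in this assay.

The expected change is a step that the limit leaves unreadable from compound 3 to compound 4. For compound 4 the estimated value is 15 ug/mL, with an expected range from 6 ug/mL to 40 ug/mL, and a report as a limit is the likeliest outcome.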

Compound 4, half-maximal inhibitory concentration: > 10 ug/mL
Compound 4: a limit, no number; the forecaster's own chance of this, stated with the estimate: 80%; the middle value lies beyond the limit too.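

Compound 4 gives only a limit, so its steps to compound 1, compound 2 and compound 3 cannot be read, and no new step emerges: the limit of > 10 ug/mL in this assay, at which 4 of the 4 values shown sit.

The compounds shown leave open what number any of them would reach in this assay, and whether exchanging one of these groups for another changes it at all.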